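The source may hold more compounds than are shown below. What is called first, only, known or untested is meant among the compounds shown, and "the series" means these compounds.

Measured in a physicochemical assay for solubility, read by LC-MS, in phosphate buffer, measured as thermodynamic solubility, with a stated time of 24 h, at pH 7.4; on this read-out higher numbers stand for higher solubility and lower numbers for lower solubility:
compound 1 `Cn1cc(-c2cnc3[nH]cc(-c4ccc(F)cc4)c3c2)cn1` gives 9000 nM
compound 2 `Cn1cc(-c2cnc3[nH]cc(-c4ccc(C(N)=O)cc4)c3c2)cn1` gives 3000 nM
compound 3 `Cn1cc(-c2cnc3[nH]cc(-c4ccc(C(=O)O)cc4)c3c2)cn1` gives 850000 nM

Compound 1 stands second highest of the three. Compound 4 `Cn1cc(-c2cnc3[nH]cc(C4CCNC4)c3c2)cn1` carries pyrrolidin-3-yl in place of 4-fluorophenyl on an aromatic carbon. Going by the values given here, no measured step replaces the whole 4-fluorophenyl, so the evidence is indirect. Compound 3 supports an upward move, with a 94-fold higher number from compound 1 to compound 3 (1.98 log units; beyond the scatter). Compound 2 goes against it, with a 3.0-fold lower number from compound 1 to compound 2 (0.48 log units; beyond the scatter). A large upward step in this assay is expected, with low confidence in its size. The expected step is a 17-fold higher number from compound 1 to compound 4 (1.22 log units; beyond the scatter). For compound 4 the estimate is 150000 nM, with an expected range of 20000 nM to 800000 nM.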

Compound 4, solubility: 1000000 nM
Estimate against measurement, compound 4: 6.7-fold (0.82 log units) below; the measured number lies above the stated range.
By their numbers in this assay, from the lowest: compound 2; then compound 1; then compounds 3 and 4 (each within the scatter of the next).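

Exchanging the whole 4-fluorophenyl for pyrrolidin-3-yl on this aromatic carbon gives a 110-fold higher number from compound 1 to compound 4 (2.05 log units; beyond the scatter) in this assay, so a high number here does not require a six-membered aromatic ring or a carboxy group. Compound 4 and compound 3 lie within the scatter of each other at the top of the series. Going by these compounds alone, nothing measured so far accounts for the step.

As far as these compounds go, the step changes the ring and brings in the ring nitrogen together, so their shares remain open. A cyclopentyl group or an acyclic amine chain at this place would bear on that.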